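Ethoxy to dimethylamino: working notes on compound 4

This account rests on a few compounds, and the source may have more. Where it says the series, first, only, none or still open, it means among the compounds named here.

Values in a functional assay on MCF7 cells (Homo sapiens) for antiproliferative activity, read by MTT assay, with a stated time of 48 h (a higher number here means a weaker inhibitor, a lower number a stronger inhibitor), so far
compound 1 `C=C(c1cc(OC)c(OC)c(OC)c1)c1ccc(OC)c(O)c1NC(C)=O` gives 270 nM
compound 2 `C=C(c1cc(OC)c(OC)c(OC)c1)c1ccc(OC)c(O)c1NC(=O)COC` gives 560 nM
compound 3 `C=C(c1cc(OC)c(OC)c(OC)c1)c1ccc(OC)c(O)c1NC(=O)COCC` gives 1050 nM

Compound 3 stands within the scatter of compound 2 (a 1.9-fold higher number from compound 2 to compound 3 (0.27 log units; within the scatter)) and beyond it from compound 1 (a 3.9-fold higher number from compound 1 to compound 3 (0.59 log units; beyond the scatter)). The next change gives compound 4 `C=C(c1cc(OC)c(OC)c(OC)c1)c1ccc(OC)c(O)c1NC(=O)CN(C)C` and places dimethylamino in place of ethoxy on a saturated chain carbon bound to a carbonyl carbon. The measured steps that bear on it at this carbon (a 2.1-fold higher number from compound 1 to compound 2 (0.32 log units; beyond the scatter) and a 3.9-fold higher number from compound 1 to compound 3 (0.59 log units; beyond the scatter)) were both modest and both led to a higher number. Among the compounds with values here, no measured compound carries dimethylamino, so no direction can be argued and no change beyond the scatter is expected. The expected step is a 1.1-fold lower number from compound 3 to compound 4 (0.02 log units; within the scatter) and it remains an estimate. For compound 4 the estimated value is 1000 nM with 350 nM to 3000 nM as its range.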

Compound 4, half-maximal inhibitory concentration: 210 nM
Estimate against measurement, compound 4: 4.8-fold (0.68 log units) above; measured number below the stated range.
By their numbers in this assay, from the lowest: compounds 4 and 1 (each within the scatter of the next); then compounds 2 and 3 (each within the scatter of the next).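

At this saturated chain carbon bound to a carbonyl carbon, substitution does not always raise the number in this assay: dimethylamino in place of ethoxy gives (a 5.0-fold lower number from compound 3 to compound 4 (0.70 log units; beyond the scatter)), and dimethylamino in place of methoxy gives (a 2.7-fold lower number from compound 2 to compound 4 (0.43 log units; beyond the scatter)). Against hydrogen, dimethylamino stays within the scatter (a 1.3-fold lower number from compound 1 to compound 4 (0.11 log units; within the scatter)), so the higher numbers of the two ether-bearing compounds do not extend to this amine. No measurement here accounts for the difference.

Going by these compounds, whether diethylamino or a longer chain carrying dimethylamino at this carbon would keep the number of compound 4 remains open.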